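Three Measured Compounds and One Expected Value

The compounds below may be only part of what the source reports. "The series", "measured", "known", "first", "only" and "open" are said of these compounds alone.

Three compounds share one core and differ only in the group attached on an aromatic carbon of the five-membered ring. Compound 1 `O=C(NO)c1ccc(NCc2nc(-c3cccnc3)nn2-c2ccccc2)cc1` carries a pyridin-3-yl group and gives 57.7% in an assay on Sf9 cells for inhibition of protein deacetylase HDAC6 (Homo sapiens), read by fluorescence, with a stated time of 40 min, tested at 100 nM; on this read-out lower numbers stand for less inhibition and higher numbers for more inhibition at the one concentration tested (going by the name of the read-out). Compound 2 `O=C(NO)c1ccc(NCc2nc(-c3cccc(Cl)c3)nn2-c2ccccc2)cc1` carries a 3-chlorophenyl group and gives 61.2%. Compound 3 `O=C(NO)c1ccc(NCc2nc(-c3cc4ccccc4s3)nn2-c2ccccc2)cc1` carries a 1-benzothiophen-2-yl group and gives 65.5%. The steps between them are all small: a number 3.5 percentage points higher from compound 1 to compound 2 (within the scatter), a number 7.8 percentage points higher from compound 1 to compound 3 (within the scatter) and a number 4.3 percentage points higher from compound 2 to compound 3 (within the scatter). Compound 3 thus holds the highest of the three numbers, but its gaps to compound 2 and to compound 1 lie within the scatter, so no order among the three can be claimed.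

Compound 4 `CCc1ccc(-c2nc(CNc3ccc(C(=O)NO)cc3)n(-c3ccccc3)n2)cc1` changes the same position once more: 4-ethylphenyl in place of 1-benzothiophen-2-yl on an aromatic carbon.

All three measured steps bear on this change, since each swaps the group at this same position, and none of them moved the read-out beyond the scatter. A fourth swap at the same position is therefore expected to behave alike: a step of no clear direction, within the scatter. Compound 4 is expected to give about 60%, with a likely range from 46% to 74%. The expected step of a number 5.5 percentage points lower from compound 3 to compound 4 (within the scatter) is estimated to stay within the scatter.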

Compound 4, a percentage reported as inhibition, at one concentration (the size of the read-out at that concentration, not a potency): 54.6%
Estimate against measurement, compound 4: 5.4 percentage points above, and the stated range covers the measured number.
By their numbers in this assay, from the lowest: compounds 4, 1, 2 and 3 (each within the scatter of the next, the first and the last beyond it).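

In this assay, among these compounds, the earlier swaps at this position stayed within the scatter, but the change to 4-ethylphenyl gives a number 10.9 percentage points lower from compound 3 to compound 4 (beyond the scatter) and so provides the first sign that the group on this aromatic carbon can shift the read-out, if only modestly. This separation holds for one pair only, since the same group gives a number 6.6 percentage points lower from compound 2 to compound 4 (within the scatter) and a number 3.1 percentage points lower from compound 1 to compound 4 (within the scatter), which leaves the 3-chlorophenyl and pyridin-3-yl compounds unresolved from the 4-ethylphenyl compound and from each other, so the four groups do not form a firm ranking. No measurement at hand accounts for the gap between the 1-benzothiophen-2-yl and 4-ethylphenyl groups.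

As far as these compounds go, all four groups at this position contain an aromatic ring, so it remains open how the read-out would respond to a non-aromatic group such as an amine, a carboxylic acid or a longer alkyl chain. From the compounds shown here alone, it is also open whether the modest gap would hold across a range of concentrations, as each number here is the size of the read-out at one concentration and not a potency.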